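The source may report more compounds than this note shows. Statements on the series, on what has been measured and on what is new or still open speak of the compounds shown alone.

Compound 1, with the structure `O=C(OC1(C(=O)Nc2ccc([N+](=O)[O-])cc2)CCCCC1)c1ccc(C(F)(F)F)cc1`, was tested in an ADME assay on WI-38 cells (Homo sapiens) for inhibition, read by MTT assay, with a stated time of 72 h (on this read-out higher numbers stand for weaker inhibition and lower numbers for stronger inhibition), and gave 185 nM. Compound 2, with the structure `O=C(/C=C/c1ccccc1)OC1(C(=O)Nc2ccc([N+](=O)[O-])cc2)CCCCC1`, gave in this assay a value of 41 nM. Among the measured compounds shown here, of these two numbers compound 1 holds the highest, so it is the weaker inhibitor of the pair; the only measured step, a 4.5-fold lower number from compound 1 to compound 2 (0.65 log units; beyond the scatter), exchanges the group on the carbonyl carbon, and its size lies beyond the scatter.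

Compound 3, with the structure `O=C(OC1(C(=O)Nc2ccc([N+](=O)[O-])cc2)CCCCC1)C(O)c1ccccc1`, has not yet been measured. It differs from compound 1 in this way: hydroxy(phenyl)methyl in place of 4-(trifluoromethyl)phenyl on a carbonyl carbon. For the measured compounds named here, the change sits at the same carbonyl carbon that the step from compound 1 to compound 2 altered, so that step is the only guide available, though the entering group here is not the same. Because that step was a 4.5-fold lower number from compound 1 to compound 2 (0.65 log units; beyond the scatter), a change at this position can move the number by a modest amount downward. For compound 3 the expected step is a 1.7-fold lower number from compound 1 to compound 3 (0.23 log units; within the scatter), a smaller shift than the measured one, with wide uncertainty. Compound 3 is therefore estimated to give 110 nM, within a range from 35 nM to 350 nM.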

Compound 3, half-maximal inhibitory concentration: 84.4 nM
Compound 3: middle estimate off by 1.3-fold (0.12 log units), on the high side; the measured number falls inside the stated range.
By their numbers in this assay, from the lowest: compound 2; then compound 3; then compound 1.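

In this assay, a second replacement at this carbonyl carbon also lowers the number, with a 2.2-fold lower number from compound 1 to compound 3 (0.34 log units; beyond the scatter), so both groups tried in place of 4-(trifluoromethyl)phenyl give stronger inhibition. The two replacements are not equivalent, however: a 2.1-fold higher number from compound 2 to compound 3 (0.31 log units; beyond the scatter), which places the three groups in a clear order, with 2-phenylethenyl giving the strongest inhibition, hydroxy(phenyl)methyl the next strongest and 4-(trifluoromethyl)phenyl the weakest. This position therefore responds to the choice of group even when each group carries a phenyl ring, but no supporting measurement accounts for this order.

The compounds shown leave open whether the hydroxy group of hydroxy(phenyl)methyl matters to the number, a question that a plain phenylmethyl group, or a version with an amine in place of the hydroxy group, would address directly. They also leave open whether an aromatic ring is needed here at all, since every group shown contains one, and a simple butyl chain or a carboxylic acid on a short chain at this carbonyl carbon would test that.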